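Replacing a fused ring with a styryl group on the amide

The source may hold more compounds than are shown below. What is called first, only, known or untested is meant among the compounds shown, and "the series" means these compounds.

Measured compounds in a functional assay on HepG2 cells (Homo sapiens) for cytotoxicity, read by MTT assay, with a stated time of 48 h; a lower number here means a stronger inhibitor, a higher number a weaker inhibitor:
- compound 1 `CCCCCCCCCCCCCCNC(=O)[C@@H](NC(=O)/C=C/c1ccccc1)[C@@H](C)O` gives 150000 nM
- compound 2 `CCCCCCCCCCCCCCCCCCNC(=O)[C@@H](NC(=O)c1ccco1)[C@@H](C)O` gives 42300 nM
- compound 3 `CCCCCCCCCCCCCCCCCCNC(=O)[C@@H](NC(=O)c1cc2ccccc2o1)[C@@H](C)O` gives > 200000 nM, which is a limit of the assay and not a number.

Compound 3 therefore stands at the weak end of what has been measured: in this assay it gave only a limit, so its true value is not known. Among the compounds with values here, the one step that reaches compound 3 is an at least 4.7-fold higher number from compound 2 to compound 3 (0.67 log units; beyond the scatter), and the size of that step is itself only a lower bound because of the limit of > 200000 nM in this assay, at which 1 of the 3 values shown sits.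

Compound 4 `CCCCCCCCCCCCCCCCCCNC(=O)[C@@H](NC(=O)/C=C/c1ccccc1)[C@@H](C)O` differs from compound 3 by 2-phenylethenyl in place of 1-benzofuran-2-yl on a carbonyl carbon. Within the data shown here, no measured step covers exactly this change. The closest guide is compound 1, which carries the same 2-phenylethenyl group on a shorter chain and in this assay sits at a measurable but weak value. Compound 4 is therefore expected to return a number close to that of compound 1, so the estimated step of an at least 1.3-fold lower number from compound 3 to compound 4 (0.12 log units; that floor lies within the scatter) is uncertain in size. The estimate for compound 4 is 150000 nM, with a range from 50000 nM to 300000 nM.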

Compound 4, half-maximal inhibitory concentration: 128000 nM
Compound 4: the middle estimate sits 1.2-fold (0.07 log units) above what was measured; the measured number falls inside the stated range.
By their numbers in this assay, from the lowest: compound 2; then compounds 4 and 1 (each within the scatter of the next). At a limit, above all of these: compound 3.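

In this assay, the 2-phenylethenyl group on the longer chain gives a measured number, but the furan-2-yl group still holds the lower number, with a 3.0-fold higher number from compound 2 to compound 4 (0.48 log units; beyond the scatter) on replacing it. Butyl in place of hydrogen on the chain leaves the value within the scatter, with a 1.2-fold lower number from compound 1 to compound 4 (0.07 log units; within the scatter) for that change, so the two chain lengths cannot be told apart when the 2-phenylethenyl group is present. Against the 1-benzofuran-2-yl group, only a floor can be read, an at least 1.5-fold lower number from compound 3 to compound 4 (0.19 log units; that floor lies within the scatter) as the step, since compound 3 stands at a limit of the assay and not at a number: the limit of > 200000 nM in this assay, at which 1 of the 4 values shown sits.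

The compounds shown leave open whether the furan-2-yl group would keep its lower number on the shorter chain. They also do not show what an amine or a carboxylic acid on the phenyl ring of the 2-phenylethenyl group would do, or a chain longer than that of compound 4.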